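Aspirin Diester Plasma Half-lives and a Nitrooxymethyl Analogue

The source may report more compounds than this note shows. Statements on the series, on what has been measured and on what is new or still open speak of the compounds shown alone.

Measured compounds:
Compound 1, `CC(=O)Oc1ccccc1C(=O)O[C@H]1CO[C@H]2[C@@H]1OC[C@H]2OC(=O)c1cccc(O)c1`: 0.0183 h
Compound 2, `CC(=O)Oc1ccccc1C(=O)O[C@H]1CO[C@H]2[C@@H]1OC[C@H]2OC(=O)c1ccccc1OC(=O)c1ccccc1`: 0.385 h

In an ADME assay on a cell-free system (plasma, Homo sapiens) for metabolic stability, with Plasma (Rattus norvegicus) as the target, read by HPLC, at pH 7.4 (on this read-out lower numbers stand for a shorter-lived compound and higher numbers for a longer-lived compound), compound 1 gives 0.0183 h, while compound 2 gives 0.385 h. Compound 2 therefore stands highest of the two numbers, with compound 1 the nearest and well beyond the usual scatter from it.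

Compound 3, `CC(=O)Oc1ccccc1C(=O)O[C@H]1CO[C@H]2[C@@H]1OC[C@H]2OC(=O)c1ccccc1CO[N+](=O)[O-]`, has not yet been measured in this assay. It differs from compound 2 in one place: (nitrooxy)methyl in place of benzoyloxy on an aromatic carbon. Within the data shown here, no measured pair shows this kind of change, so the direction cannot be read from the data; only compound 1 and compound 2 are known, and they differ elsewhere.

Because compound 2 gives 0.385 h, compound 3 is expected to stay near that number, with a step of a 1.3-fold lower number from compound 2 to compound 3 (0.11 log units; within the scatter) that is estimated to be small or none beyond the scatter. Compound 3 is estimated at 0.3 h, within 0.1 h to 1 h.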

Compound 3, half-life: 0.045 h
The estimate for compound 3 lay 6.7-fold (0.82 log units) above the measured number; the whole stated range lies above it.
By their numbers in this assay, from the lowest: compound 1; then compound 3; then compound 2.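

Among these compounds, putting (nitrooxy)methyl in place of benzoyloxy on this aromatic carbon, ortho to a large group, gives the first single change at this position that can be read: in this assay there is an 8.6-fold lower number from compound 2 to compound 3 (0.93 log units; beyond the scatter), so the group held here matters for the half-life. The other step, a 2.5-fold higher number from compound 1 to compound 3 (0.39 log units; beyond the scatter), comes with 2-((nitrooxy)methyl)phenyl in place of 3-hydroxyphenyl on a carbonyl carbon, which leaves compound 3 between the two earlier compounds rather than level with compound 2. Nothing available accounts for the size or direction of either step.

Going by these compounds, whether the shorter half-life follows the arrival of the nitrooxy part or the departure of benzoyloxy stays open, and a hydroxymethyl group on the same aromatic carbon would separate the two. Also open, on these data alone, is whether the step would hold with an amide in place of the ester link on that carbonyl carbon.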